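This account rests on a few compounds, and the source may have more. Where it says the series, first, only, none or still open, it means among the compounds named here.

Measured so far:
compound 1 `Nc1nc(O)nc2c1nc(O)n2Cc1ccccc1`, 0.1 uM
compound 2 `CCCCc1nc(N)c2nc(O)n(Cc3ccccc3)c2n1`, 0.03 uM
compound 3 `CCc1nc(N)c2nc(O)n(Cc3ccccc3)c2n1`, 1 uM

In a functional assay (spleen, spleen) for activation, with Mus musculus as the target (a lower number here means that less compound is needed, a higher number that more compound is needed for the effect), compound 3 needs the most compound of the three. The step from compound 1, which carries a hydroxy group at this carbon, was a 10-fold higher number from compound 1 to compound 3 (1.00 log units; beyond the scatter); the butyl analogue went the other way, a 3.3-fold lower number from compound 1 to compound 2 (0.52 log units; beyond the scatter), and a 33-fold higher number from compound 2 to compound 3 (1.52 log units; beyond the scatter).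

Compound 4 `Nc1nc(N)c2nc(O)n(Cc3ccccc3)c2n1` differs from compound 3 by amino in place of ethyl on an aromatic carbon. For the measured compounds named here, no measured step replaces an alkyl group by an amino group, so the expectation rests on compound 1, which in this assay gives 0.1 uM with a hydroxy group at the same carbon. A step of about a 6.7-fold lower number from compound 3 to compound 4 (0.82 log units; beyond the scatter) is therefore expected. For compound 4 the estimated value is 0.15 uM, with a range from 0.03 uM to 0.6 uM.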

Compound 4, minimum effective concentration: 10 uM
The estimate for compound 4 lay 67-fold (1.82 log units) below the measured number; the measured number lies above the stated range.
By their numbers in this assay, from the lowest: compound 2; then compound 1; then compound 3; then compound 4.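

At this aromatic carbon, amino gives the highest number of the four groups in this assay, with a 10-fold higher number from compound 3 to compound 4 (1.00 log units; beyond the scatter), a 100-fold higher number from compound 1 to compound 4 (2.00 log units; beyond the scatter) and a 330-fold higher number from compound 2 to compound 4 (2.52 log units; beyond the scatter). Amino therefore does not stand in for hydroxy here, and the order does not follow heavy-atom count, since compound 1 with hydroxy and compound 2 with butyl both need less compound than compound 3 with ethyl. Nothing measured here explains this order.

The compounds shown leave open how a propyl or a pentyl chain would fall relative to ethyl and butyl. They also leave open whether a methoxy group at this carbon would track hydroxy.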